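A Thiazolylsulfamoyl Group Replaces the Carboxymethyl Arm

A few compounds are considered here, and "the series" means these few. Any claim that something is new, unique, unknown or untested is made for them only; others in the source may bear on it.

Compound 3 `O=C(O)Cc1ccc(NC(=O)c2cn(Cc3c(F)cccc3F)c3ccc(=O)[nH]c3c2=O)cc1` gives 176 nM in an in vitro assay on Sf21 cells for inhibition of high affinity 3',5'-cyclic-AMP phosphodiesterase 7A (Homo sapiens), read by scintillation proximity assay, with a stated time of 30 min; on this read-out higher numbers stand for weaker inhibition and lower numbers for stronger inhibition; its number stands second highest of the three, with compound 1 `O=C(Nc1ccccc1)c1cn(Cc2c(F)cccc2F)c2ccc(=O)[nH]c2c1=O` nearest at 94 nM and compound 2 `N#Cc1cccc(NC(=O)c2cn(Cc3c(F)cccc3F)c3ccc(=O)[nH]c3c2=O)c1` furthest at 1070 nM. Compound 4 `O=C(Nc1ccc(S(=O)(=O)Nc2nccs2)cc1)c1cn(Cc2c(F)cccc2F)c2ccc(=O)[nH]c2c1=O` carries (1,3-thiazol-2-yl)sulfamoyl in place of carboxymethyl on an aromatic carbon. For the measured compounds named here, two measured steps bear on substitution at this aromatic carbon: a 1.9-fold higher number from compound 1 to compound 3 (0.27 log units; within the scatter) and a 6.1-fold lower number from compound 2 to compound 3 (0.78 log units; beyond the scatter), while an 11-fold higher number from compound 1 to compound 2 (1.06 log units; beyond the scatter) shows that a cyano at another position cost more. Going by the values given here, the group entering compound 4 is larger than anything measured here, so no step gives a direct guide. The expected step is a 1.3-fold higher number from compound 3 to compound 4 (0.10 log units; within the scatter), a change not beyond the scatter. Compound 4 is estimated at 220 nM, with a range from 60 nM to 800 nM.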

Compound 4, half-maximal inhibitory concentration: 25 nM
Estimate against measurement, compound 4: 8.8-fold (0.94 log units) above; the measured number lies below the stated range.
By their numbers in this assay, from the lowest: compound 4; then compounds 1 and 3 (each within the scatter of the next); then compound 2.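

At this aromatic carbon, para to a large group, carboxymethyl had stayed within the scatter of hydrogen, but (1,3-thiazol-2-yl)sulfamoyl gives a 7.0-fold lower number from compound 3 to compound 4 (0.85 log units; beyond the scatter) and a 3.8-fold lower number from compound 1 to compound 4 (0.58 log units; beyond the scatter), so a substituent here can strengthen inhibition beyond the unsubstituted compound 1. The change replaces carboxymethyl with a larger group containing a five-membered aromatic ring, so this single step cannot assign the gain to any one part of it. Nothing measured here explains the gain. The compounds shown leave open whether a plain sulfamoyl group without the ring would do the same, and whether a phenyl ring could replace the 1,3-thiazol-2-yl ring.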